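Trading the chain-end cyano for a methyl

The source may report more compounds than this note shows. Statements on the series, on what has been measured and on what is new or still open speak of the compounds shown alone.

Three close relatives share one core. Compound 1 `CCc1cc(C(C)=O)c(O)cc1OCCCCCCC#N` gives 103% in an assay on isolated protein for inhibition of leukotriene B4 receptor 1 (Homo sapiens), tested at 10 uM; a lower number here means less inhibition, a higher number more inhibition at the concentration tested (going by the name of the read-out). Within the data shown here, compound 3 `CCc1cc(C(C)=O)c(O)cc1OCCCCCCC(C)(C)C#N` gives 65%, and the single change behind that pair produced a number 38 percentage points lower from compound 1 to compound 3 (beyond the scatter). Compound 2 `C=CCc1cc(C(C)=O)c(O)cc1OCCCCCC#N` gives 81%: it stands second highest of the three numbers, below compound 1 by a margin beyond the scatter and above compound 3 by a margin also beyond the scatter.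

Compound 4 `C=CCc1cc(C(C)=O)c(O)cc1OCCCCCC` has not yet been measured. It differs from compound 2 in one place: methyl in place of cyano on a saturated chain carbon, five bonds along the chain from an oxygen on an aromatic ring. Among the measured compounds shown here, no measured step removes the cyano outright, so the only guidance is the step from compound 1 to compound 3, where altering the chain end around the cyano lowered inhibition by a large amount. On that basis a drop beyond the scatter is expected for compound 4, though its size is uncertain. Compound 4 is therefore estimated at 45%, within a range from 15% to 75%, which corresponds to an expected step of a number 36 percentage points lower from compound 2 to compound 4 (beyond the scatter).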

Compound 4, a percentage reported as inhibition, at one concentration (the size of the read-out at that concentration, not a potency): 50%
Beside the measured number, compound 4's estimate is 5 percentage points below it; the range from low to high includes it.
By their numbers in this assay, from the lowest: compound 4; then compound 3; then compound 2; then compound 1.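

Among these compounds, this is the first compound in the set to lose the cyano group altogether, rather than have the chain end altered around it. In this assay the swap of cyano for methyl gives a number 31 percentage points lower from compound 2 to compound 4 (beyond the scatter), so at this position, five bonds along the chain from the oxygen on the aromatic ring, the two groups are not interchangeable. Even so, compound 4 still gives 50%, which shows that some inhibition at the concentration tested survives without the cyano group, although no measurement here explains the size of this step. As far as these compounds go, it remains open whether a carboxylic acid, an amine or an amide at the same chain end would keep inhibition closer to that of compound 2. Also unresolved is whether replacing cyano with methyl on compound 1 would produce a step of similar size.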